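Diethylamino in Place of Dimethylamino on a Shared Core

A few compounds are considered here, and "the series" means these few. Any claim that something is new, unique, unknown or untested is made for them only; others in the source may bear on it.

Measured in an assay on isolated protein for inhibition of NADPH oxidase 2 (Homo sapiens), read by chemiluminescence, in the presence of a further agent that is not named here; a lower number here means a stronger inhibitor, a higher number a weaker inhibitor:
- compound 1 `CCN(CC)c1ccc(/C=C2\C(=O)N(C3CCCCC3)C(=S)N2C)cc1`: 5660 nM
- compound 2 `CCN(CC)c1ccc(/C=C2\C(=O)N(C3CCCCC3)C(=S)N2C)c(OC)c1`: 1950 nM
- compound 3 `CN1C(=S)N(C2CCCCC2)C(=O)/C1=C\c1ccc(N(C)C)cc1O`: 2960 nM

Compound 3 stands second highest of these three numbers; compound 2 and compound 1 both lie within the scatter of it, so no order among them can be claimed. Compound 4 `CCN(CC)c1ccc(/C=C2\C(=O)N(C3CCCCC3)C(=S)N2C)c(O)c1` differs from compound 3 by diethylamino in place of dimethylamino on an aromatic carbon. Among the measured compounds shown here, no measured step covers this change directly: the only step, a 2.9-fold lower number from compound 1 to compound 2 (0.46 log units; beyond the scatter), concerns a methoxy group, not the amine. For the measured compounds named here, with no step bearing on it, the expected change from compound 3 to compound 4 in this assay is a 1.2-fold lower number from compound 3 to compound 4 (0.07 log units; within the scatter), within the scatter. Compound 4 is therefore estimated at 2500 nM, between 900 nM and 7000 nM.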

Compound 4, half-maximal inhibitory concentration: 1660 nM
Beside the measured number, compound 4's estimate is 1.5-fold (0.18 log units) above it; the range from low to high includes it.
By their numbers in this assay, from the lowest: compounds 4, 2, 3 and 1 (each within the scatter of the next, the first and the last beyond it).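

In this assay, the swap of amine gives a 1.8-fold lower number from compound 3 to compound 4 (0.25 log units; within the scatter) and so does not separate diethylamino from dimethylamino at this place, para to a large group. Hydrogen in place of methyl on the oxygen gives a 1.2-fold lower number from compound 2 to compound 4 (0.07 log units; within the scatter), whereas hydroxy in place of hydrogen gives a 3.4-fold lower number from compound 1 to compound 4 (0.53 log units; beyond the scatter) and so, like methoxy, stands beyond the scatter against the unsubstituted compound 1. Nothing measured here explains these results. As far as these compounds go, whether dipropylamino at the amine position would keep this level remains open. So does the effect of an ethoxy group in place of the hydroxy.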